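Methoxy for bromo in a cinnamoyl sulfonamide series

The compounds below may be only part of what the source reports. "The series", "measured", "known", "first", "only" and "open" are said of these compounds alone.

Three cinnamoyl sulfonamides have been measured in a functional assay on B16-F10 cells (Mus musculus) for antiproliferative activity, read by ELISA and MTT assay, with a stated time of 48 h; a higher number here means a weaker inhibitor, a lower number a stronger inhibitor. Compound 1 `O=C(/C=C/c1ccc(Br)cc1)NS(=O)(=O)c1ccc(F)cc1` gives 1.2 ug/mL. Compound 2 `O=C(/C=C/c1ccc(Br)cc1)NS(=O)(=O)c1ccc(Cl)cc1` gives 5.2 ug/mL. Compound 3 `O=C(/C=C/c1ccc(Br)cc1)NS(=O)(=O)c1ccc(Br)cc1` gives 5.1 ug/mL, which places it close to compound 2, as the step of a 1.0-fold lower number from compound 2 to compound 3 (0.01 log units; within the scatter) shows, and apart from compound 1, as the step of a 4.3-fold higher number from compound 1 to compound 3 (0.63 log units; beyond the scatter) shows. The step of a 4.3-fold higher number from compound 1 to compound 2 (0.64 log units; beyond the scatter) is of the same size.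

Compound 4 `COc1ccc(/C=C/C(=O)NS(=O)(=O)c2ccc(Br)cc2)cc1` differs from compound 3 in one place: methoxy in place of bromo on an aromatic carbon. Among the measured compounds shown here, all three measured steps exchange one halogen for another on an aromatic carbon, and none of them changes the aromatic carbon where the methoxy now enters, so no measured step bears directly on this change. The two steps that leave a halogen in place of another were modest, and the one between chloro and bromo lay within the scatter. The account therefore expects no step beyond the scatter in this assay, with the expected step from compound 3 to compound 4 being a 1.0-fold lower number from compound 3 to compound 4 (0.01 log units; within the scatter). Compound 4 is estimated to give 5 ug/mL, within a range from 1.5 ug/mL to 15 ug/mL.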

Compound 4, half-maximal inhibitory concentration: 5.8 ug/mL
Compound 4: the middle estimate sits 1.2-fold (0.06 log units) below what was measured, within the range that was stated.
By their numbers in this assay, from the lowest: compound 1; then compounds 3, 2 and 4 (each within the scatter of the next).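

In this assay, the first change shown at this place, on the ring that carries the bromo in compounds 1 to 3, gives a 1.1-fold higher number from compound 3 to compound 4 (0.06 log units; within the scatter), so bromo and methoxy cannot be told apart here. Among the compounds shown here, all the earlier steps exchanged one halogen for another at a different place, so they said nothing about this aromatic carbon. With the bromo kept on the other ring, a group that is not a halogen, with more heavy atoms and a hydrogen-bond acceptor, gave no step beyond the scatter. No measurement offered here explains this result. From the compounds shown here alone, it remains open whether methoxy would behave the same way alongside the fluoro of compound 1, where the number was lowest. An amine, a carboxylic acid or a longer chain at this carbon also remains untested in the compounds shown.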